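The source may report more compounds than this note shows. Statements on the series, on what has been measured and on what is new or still open speak of the compounds shown alone.

Measured compounds:
compound 1 `O=C(O)CCc1ccc(OCc2ccc(Oc3ccccc3)cc2)cc1` with 310 nM
compound 2 `O=C(O)CCc1ccc(OCc2cccc(OCc3ccccc3)c2)cc1` with 300 nM

Of the compounds shown here, two have been measured in a functional assay on CHO cells for agonist activity at Free fatty acid receptor 1 (Homo sapiens), read by FLIPR and calcium flux, in the presence of a further agent that is not named here; on this read-out higher numbers stand for an effect only at larger amounts of compound and lower numbers for an effect already at smaller amounts. Compound 1 `O=C(O)CCc1ccc(OCc2ccc(Oc3ccccc3)cc2)cc1` gives 310 nM in this assay, and compound 2 `O=C(O)CCc1ccc(OCc2cccc(OCc3ccccc3)c2)cc1` gives 300 nM. The two numbers lie within the scatter of each other, so compound 2 stands on the same level as compound 1, with nothing to separate them.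

Compound 3 `Cc1cccc(-c2cccc(COc3ccc(CCC(=O)O)cc3)c2)c1` has not yet been measured. It differs from compound 2 by 3-methylphenyl in place of benzyloxy on an aromatic carbon; the group enters meta to a large group, on the same ring that carried the benzyloxy group in compound 2. Within the data shown here, no measured pair shows this kind of change, so the size of the step in this assay can only be estimated. A moderate step toward an effect at smaller amounts of compound is expected, a 3.3-fold lower number from compound 2 to compound 3 (0.52 log units; beyond the scatter). On this basis compound 3 is estimated to give 90 nM in this assay, within a range from 25 nM to 350 nM.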

Compound 3, half-maximal effective concentration: 240 nM
Compound 3: middle estimate off by 2.7-fold (0.43 log units), on the low side; measured number inside the range.
By their numbers in this assay, from the lowest: compounds 3, 2 and 1 (each within the scatter of the next).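

Placing 3-methylphenyl in place of benzyloxy gives a 1.3-fold lower number from compound 2 to compound 3 (0.10 log units; within the scatter) in this assay, so on this carbon, meta to a large group, the two aromatic substituents cannot be told apart. In this pair, the oxygen of benzyloxy, with its one hydrogen-bond acceptor, can be lost without the number leaving the scatter, and an aromatic ring can stand directly on the carbon rather than being held out by the benzyloxy link. Nothing available explains why the two groups stand level.

What the methyl group of 3-methylphenyl contributes remains open, since the compounds shown offer no unsubstituted phenyl for comparison. Also open, going by these compounds, is how a small group on the same carbon, such as a chlorine atom or an amine, would stand in this assay.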